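This account rests on a few compounds, and the source may have more. Where it says the series, first, only, none or still open, it means among the compounds named here.

Measured so far in an ADME assay on Vero cells (Chlorocebus sabaeus) for cytotoxicity, read by resazurin assay, with a stated time of 3 days; a higher number here means a weaker inhibitor, a lower number a stronger inhibitor:
- compound 2, `CCN(CC)c1cc2[nH]c(C3CCCCC3)nc2cc1NC(=O)c1ccc(F)cc1`: > 100 ug/mL
- compound 1, `CCN(CC)c1cc2[nH]c(C3CCCCC3)nc2cc1NC(=O)c1ccc(N(C)C)cc1`: "not determined" (no result reported)

Compound 1, `CCN(CC)c1cc2[nH]c(C3CCCCC3)nc2cc1NC(=O)c1ccc(N(C)C)cc1`, has no result in this assay; in this assay compound 1 stands as "not determined" (no result reported). Compound 2, `CCN(CC)c1cc2[nH]c(C3CCCCC3)nc2cc1NC(=O)c1ccc(F)cc1`, reaches only the upper limit of this assay: in this assay compound 2 gives > 100 ug/mL, which is a limit and not a number (the limit of > 100 ug/mL in this assay, at which 1 of the 2 values shown sits). Within the data shown here, with one limit and one entry without a number, no step between measured compounds can be drawn here, and compound 2 cannot be placed against anything else in this assay.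

Compound 3, `CCN(CC)c1cc2[nH]c(C3CCCCC3)nc2cc1NC(=O)c1ccc(OC(F)(F)F)cc1`, differs from compound 2 by trifluoromethoxy in place of fluoro on an aromatic carbon. Among the measured compounds shown here, no measured step speaks to this change. The expected step from compound 2 to compound 3 is a number no higher from compound 2 to compound 3 (the limit leaves the size open), that is, none beyond the scatter, with the reading of compound 3 most likely again a limit of this assay. The estimate for compound 3 in this assay is 100 ug/mL, within a range of 40 ug/mL to 250 ug/mL.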

Compound 3, half-maximal inhibitory concentration: > 100 ug/mL
Compound 3 ended at the assay's limit (the forecaster's own chance of this, stated with the estimate: 65%); the middle value lies on the limit itself.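

Compound 2 and compound 3 both stand at a limit of this assay, not at a number, so no step can be read between them: the limit of > 100 ug/mL in this assay, at which 2 of the 3 values shown sit.

The compounds shown leave open at what concentration either compound would reach half-maximal inhibition in this assay, and whether any change at this place moves the reading.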